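Swapping the hydroxypiperidine for a piperazine in compound 3

The source may report more compounds than this note shows. Statements on the series, on what has been measured and on what is new or still open speak of the compounds shown alone.

The measured compounds, all tested in an assay on HEK293 cells for displacement of a labelled ligand from NPC1-like intracellular cholesterol transporter 1 (Homo sapiens); a lower number here means a stronger inhibitor, a higher number a weaker inhibitor:
- compound 1 `CC(C)(C)c1ccc(C(=O)N2CCC3(CC2)C(=O)N(CC(=O)NCCO)CN3c2ccccc2)cc1`: 1000 nM
- compound 2 `CC1(C)CC(OC(=O)CN2CN(c3ccccc3)C3(CCN(C(=O)c4ccc(C(C)(C)C)cc4)CC3)C2=O)CC(C)(C)N1`: 1300 nM
- compound 3 `CC(C)(C)c1ccc(C(=O)N2CCC3(CC2)C(=O)N(CC(=O)N2CCCC(O)C2)CN3c2ccccc2)cc1`: 12200 nM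

Compound 3 has the highest number of the three, so it is the weakest inhibitor shown. Its distance from compound 2 is a 9.4-fold higher number from compound 2 to compound 3 (0.97 log units; beyond the scatter) and from compound 1 it is a 12-fold higher number from compound 1 to compound 3 (1.09 log units; beyond the scatter), while the two stronger compounds differ from each other only by a 1.3-fold higher number from compound 1 to compound 2 (0.11 log units; within the scatter).

Compound 4 `CC(C)(C)c1ccc(C(=O)N2CCC3(CC2)C(=O)N(CC(=O)N2CCNCC2)CN3c2ccccc2)cc1` is not yet measured. It differs from compound 3 by piperazin-1-yl in place of 3-hydroxypiperidin-1-yl on a carbonyl carbon. The steps leading into compound 3 both show that the 3-hydroxypiperidin-1-yl amide weakens binding against either an open (2-hydroxyethyl)amino amide or a (2,2,6,6-tetramethylpiperidin-4-yl)oxy ester. Among the measured compounds shown here, no measured pair contains a piperazin-1-yl, so the direction must be inferred. Because compound 2, which carries a ring nitrogen bearing a hydrogen, sits at 1300 nM, a partial recovery is expected, giving an estimated step of a 3.1-fold lower number from compound 3 to compound 4 (0.48 log units; beyond the scatter). Compound 4 is thus expected to reach about 4000 nM, within a range from 1000 nM to 15000 nM.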

Compound 4, half-maximal inhibitory concentration: 22000 nM
The estimate for compound 4 lay 5.5-fold (0.74 log units) below the measured number, and the stated range ends below it.
By their numbers in this assay, from the lowest: compounds 1 and 2 (each within the scatter of the next); then compounds 3 and 4 (each within the scatter of the next).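

In this assay, a 1.8-fold higher number from compound 3 to compound 4 (0.26 log units; within the scatter) is a step within the scatter, so trading 3-hydroxypiperidin-1-yl for piperazin-1-yl on this carbonyl carbon does not separate the two ring amides. The nitrogen bearing a hydrogen in the ring of compound 4 does not bring back the level of compound 2, as a 17-fold higher number from compound 2 to compound 4 (1.23 log units; beyond the scatter) shows, and the open-chain amide also stays well apart, with a 22-fold higher number from compound 1 to compound 4 (1.34 log units; beyond the scatter) as the gap. No measurement shown here explains these differences.

The compounds leave open whether the linking atom matters, which a (2,2,6,6-tetramethylpiperidin-4-yl)amino amide would test directly against the ester of compound 2. They also leave open whether an open-chain (2-aminoethyl)amino amide would stay near compound 1 or fall with the ring amides.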